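This account rests on a few compounds, and the source may have more. Where it says the series, first, only, none or still open, it means among the compounds named here.

Working notes on the series. Compound 1 `COc1ccc2nc(C)cc(OCC(=O)NCc3cc(C)cc(C)c3)c2c1` and compound 2 `COc1ccc2nc(C)cc(OCC(=O)Nc3cccnc3)c2c1` share one core and differ only on the amide-type nitrogen. In a toxicity assay on HepG2 cells (Homo sapiens) for inhibition, read by CellTiter-Glo, with a stated time of 48 h (a higher number here means a weaker inhibitor, a lower number a stronger inhibitor), compound 1 gives only a limit, > 100000 nM. In this assay compound 2 likewise gives only a limit, > 100000 nM. The step that the two limits leave unreadable from compound 1 to compound 2 cannot be sized, since both of its ends sit at the limit of > 100000 nM in this assay, at which 2 of the 2 values shown sit. Going by the values given here, compound 2 thus stands at the limit of this assay, and the one further value shown is a limit as well.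

The next step goes from compound 2 to compound 3 `COc1ccc2nc(C)cc(OCC(=O)Nc3nccs3)c2c1`. The change is 1,3-thiazol-2-yl in place of pyridin-3-yl on an amide-type nitrogen; cut one bond further out it reads (pyridin-3-yl)amino to (1,3-thiazol-2-yl)amino. Among the compounds with values here, only one measured step touches this position, and it is unreadable because both of its values sit at the limit of > 100000 nM in this assay, at which 2 of the 2 values shown sit. The estimated step of a number no higher from compound 2 to compound 3 (the limit leaves the size open) is therefore expected to stay within the scatter, with no direction assigned. Compound 3 is expected to give about 100000 nM in this assay, in the range 50000 nM to 200000 nM, most likely again reported only as a limit.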

Compound 3, half-maximal inhibitory concentration: > 100000 nM
Compound 3 was reported as a limit (the forecaster's own chance of this, stated with the estimate: 85%); the middle value lies on the limit itself.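

In this assay compound 3 gives > 100000 nM as a limit of the assay. Going by these compounds alone, no step among compound 1, compound 2 and compound 3 can be read, because all three values sit at the same limit: the limit of > 100000 nM in this assay, at which 3 of the 3 values shown sit. The compounds shown leave open whether any group on the amide-type nitrogen gives a readable half-maximal inhibitory concentration in this assay on this shared core.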